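Swapping Fluoro for Nitro on a Tolerated Series

The source may hold more compounds than are shown below. What is called first, only, known or untested is meant among the compounds shown, and "the series" means these compounds.

Compound 1 `Cn1c(-c2ccccc2F)cnc1NC(=O)c1ccc(F)cc1` gives > 100000 nM in a toxicity assay on THP-1 cells (Homo sapiens) for inhibition (a lower number here means that less compound is tolerated, a higher number that more compound is tolerated), as a limit
Compound 2 `COc1cccc(-c2cnc(NC(=O)c3ccc(F)cc3)n2C)c1` gives > 100000 nM in this assay as a limit
Compound 3 `Cn1c(-c2ccc(F)cc2)cnc1NC(=O)c1ccc(F)cc1` gives > 100000 nM in this assay as a limit

Compound 1 has no exact number in this assay and stands only at its limit of > 100000 nM here. Within the data shown here, the wider picture is the limit of > 100000 nM in this assay, at which 3 of the 3 values shown sit, and no measured compound gives an exact value. The change to compound 4 `Cn1c(-c2ccccc2[N+](=O)[O-])cnc1NC(=O)c1ccc(F)cc1` is nitro in place of fluoro on an aromatic carbon, ortho to a large group, and it counts as nitro in place of fluoro on an aromatic carbon in full. Among the measured compounds shown here, no measured compound carries a nitro, so the series does not test this group directly. The nearest evidence comes from changes to the same aromatic substituent, namely a step that the two limits leave unreadable from compound 1 to compound 2 and a step that the two limits leave unreadable from compound 1 to compound 3 and also a step that the two limits leave unreadable from compound 2 to compound 3 as a third comparison. None of these has a readable size, yet all three leave the compounds at the same limit. No step beyond the usual scatter is therefore expected, and the estimated outcome is a number no higher from compound 1 to compound 4 (the limit leaves the size open) in this assay with no direction assumed. Compound 4 is estimated at 100000 nM with an expected range from 30000 nM to 200000 nM in this read-out.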

Compound 4, half-maximal cytotoxic concentration: 31000 nM
For compound 4 the middle estimate is 3.2-fold (0.51 log units) above the measured one, and the stated range covers the measured number.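

In this assay, nitro in place of fluoro on an aromatic carbon, ortho to a large group, gives an at least 3.2-fold lower number from compound 1 to compound 4 (0.50 log units; beyond the scatter), so less compound is tolerated. The earlier changes to this aryl substituent could not be read, and this step shows that the substituent can bring the number down within the range of the assay. Compound 4 alone gives an exact value, while the other compounds stay at a limit: the limit of > 100000 nM in this assay, at which 3 of the 4 values shown sit.

The compounds shown leave open whether a nitro elsewhere on this ring would lower the number too, and whether an amine or a nitrile ortho to a large group would do the same. As far as these compounds go, the full size of the step also stays open, as compound 1 has only a limit.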